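A Fluorine Added to the Benzyl Group of Compound 3

This account rests on a few compounds, and the source may have more. Where it says the series, first, only, none or still open, it means among the compounds named here.

Of the compounds shown here, three sharing one core have been tested in an ADME assay on KB cells (Homo sapiens) for cytotoxicity; a lower number here means that less compound is needed, a higher number that more compound is needed for the effect. Compound 1 `COc1cc2c(c(O)c1OC)C(=O)[C@]1(OC)C=C[C@H]2N(C(=O)OCC(C)C)N1C(=O)OCC(C)C` carries a free hydroxyl on its aromatic ring; in this assay compound 1 gives only a limit, > 300 ug/mL (the limit of > 300 ug/mL in this assay, at which 1 of the 3 values shown sits). Compound 2 `CCCOc1c(OC)c(OC)cc2c1C(=O)[C@]1(OC)C=C[C@H]2N(C(=O)OCC(C)C)N1C(=O)OCC(C)C` has a propyl group on that oxygen, and in this assay compound 2 gives 299 ug/mL; the step of a number no higher from compound 1 to compound 2 (the limit leaves the size open) cannot be sized. Compound 3 `COc1cc2c(c(OCc3ccccc3)c1OC)C(=O)[C@]1(OC)C=C[C@H]2N(C(=O)OCC(C)C)N1C(=O)OCC(C)C` has a benzyl group on that oxygen, and in this assay compound 3 gives 94 ug/mL, the lowest of the two numbers; its nearest neighbour is compound 2, with a 3.2-fold lower number from compound 2 to compound 3 (0.50 log units; beyond the scatter), and against compound 1 the step is an at least 3.1-fold lower number from compound 1 to compound 3 (0.50 log units; beyond the scatter).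

Compound 4 `COc1cc2c(c(OCc3ccccc3F)c1OC)C(=O)[C@]1(OC)C=C[C@H]2N(C(=O)OCC(C)C)N1C(=O)OCC(C)C` differs from compound 3 in one place: fluoro in place of hydrogen on an aromatic carbon, so that benzyl becomes 2-fluorobenzyl. Going by the values given here, no measured step here puts a fluoro onto an aromatic ring; the steps that exist all concern the group on the oxygen itself. For compound 4 only a small step is therefore expected, a 1.2-fold lower number from compound 3 to compound 4 (0.07 log units; within the scatter), within the scatter. In this assay compound 4 is expected to give about 80 ug/mL, between 40 ug/mL and 160 ug/mL.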

Compound 4, concentration for half-maximal effect: 109 ug/mL
For compound 4 the middle estimate is 1.4-fold (0.13 log units) below the measured one; low and high end bracket the measured number.
By their numbers in this assay, from the lowest: compounds 3 and 4 (each within the scatter of the next); then compound 2. At a limit, above all of these: compound 1.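

In this assay, fluoro can replace hydrogen on this aromatic carbon, ortho to a large group, with no readable change: a 1.2-fold higher number from compound 3 to compound 4 (0.06 log units; within the scatter), within the scatter. The gain seen for benzyl over propyl also persists with 2-fluorobenzyl, with a 2.7-fold lower number from compound 2 to compound 4 (0.44 log units; beyond the scatter), which is beyond the scatter, so this fluoro does not remove that gain. Compound 1 gives only a limit, so an at least 2.7-fold lower number from compound 1 to compound 4 (0.43 log units; beyond the scatter) fixes a smallest size for that step and no actual size: the limit of > 300 ug/mL in this assay, at which 1 of the 4 values shown sits.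

On these data alone, whether a chlorine, a methoxy group or an amine on this same aromatic carbon would move the number remains open. So does the effect of a longer chain on the oxygen, such as phenylethyl in place of benzyl.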